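The source may report more compounds than this note shows. Statements on the series, on what has been measured and on what is new or still open speak of the compounds shown alone.

Working notes on the series. In a functional assay on HCT-116 cells (Homo sapiens) for antiproliferative activity, with a stated time of 72 h (on this read-out higher numbers stand for weaker inhibition and lower numbers for stronger inhibition), compound 1 `O=C(COc1ccc(C(=O)NC2CC=C(c3c[nH]c4cccc(F)c34)CC2)cc1)NO` gives > 5000 nM as a limit and not a number. Compound 2 `Cc1[nH]c2ccccc2c1C1=CCN(C(=O)c2ccc(OCC(=O)NO)cc2)CC1` gives > 5000 nM in this assay as a limit too, so it has no exact value. So far the series offers only the limit of > 5000 nM in this assay, at which 2 of the 2 values shown sit, and no number. Compound 3 `O=C(COc1ccc(C(=O)N2CC=C(c3c[nH]c4ccc(F)cc34)CC2)cc1)NO` has 5-fluoro-1H-indol-3-yl in place of 2-methyl-1H-indol-3-yl on a double-bonded ring carbon. Going by the values given here, no measured step between compounds sizes this change. In this assay a step that the limit leaves unreadable from compound 2 to compound 3 is expected, none beyond the scatter and in no firm direction. For compound 3 the expected value is 6000 nM with an estimated range of 2000 nM to 20000 nM in this assay as the working figure.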

Compound 3, half-maximal inhibitory concentration: > 5000 nM
Compound 3: only a limit was reported (the forecaster's own chance of this, stated with the estimate: 70%); the middle value does not contradict the limit.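

No step can be read between compound 2 and compound 3: each gives only a limit, not a number, in this assay. As far as these compounds go, whether 5-fluoro-1H-indol-3-yl in place of 2-methyl-1H-indol-3-yl shifts the read-out at all, and in which direction, stays open.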